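A few compounds are considered here, and "the series" means these few. Any claim that something is new, unique, unknown or untested is made for them only; others in the source may bear on it.

Compound 1 `Nc1ccn([C@H]2C[C@H](O)[C@@](/C=C/Cl)(CO)O2)c(=O)n1` — 200000 nM
Compound 2 `C[C@]1(CO)O[C@@H](n2ccc(N)nc2=O)C[C@@H]1O` — 160 nM

In a functional assay on L1210 cells (Mus musculus) for cytotoxicity (a higher number here means a weaker inhibitor, a lower number a stronger inhibitor), compound 1 gives 200000 nM, the highest of the two numbers measured; the nearest is compound 2, which in this assay gives 160 nM.

Compound 3 `CC[C@]1(CO)O[C@@H](n2ccc(N)nc2=O)C[C@@H]1O` has not yet been measured. It differs from compound 1 in one place: ethyl in place of 2-chloroethenyl on a saturated ring carbon. Going by the values given here, the one measured step that bears on this is the step from compound 1 to compound 2, where a 1300-fold lower number from compound 1 to compound 2 (3.10 log units; beyond the scatter); there the same 2-chloroethenyl group was exchanged for a methyl on the same saturated ring carbon. The ethyl of compound 3 is a small saturated group like the methyl of compound 2, differing from it by the heavy-atom count given, so a large drop in the number is expected in this assay, though possibly not the full size seen with methyl. Compound 3 is therefore expected to show a 67-fold lower number from compound 1 to compound 3 (1.82 log units; beyond the scatter), and its value in this assay is estimated at 3000 nM, with a range from 300 nM to 30000 nM.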

Compound 3, half-maximal inhibitory concentration: 55000 nM
Compound 3: middle estimate off by 18-fold (1.26 log units), on the low side; measured number above the stated range.
By their numbers in this assay, from the lowest: compound 2; then compound 3; then compound 1.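

In this assay, replacing 2-chloroethenyl with ethyl on this saturated ring carbon gives only a 3.6-fold lower number from compound 1 to compound 3 (0.56 log units; beyond the scatter), so a small saturated group at this place does not by itself bring the large drop seen with methyl. Lengthening the methyl by one carbon, methyl in place of hydrogen on a saturated chain carbon bound to a saturated ring carbon, produces a 340-fold higher number from compound 2 to compound 3 (2.54 log units; beyond the scatter), and this single added carbon thus accounts for most of the distance between compound 2 and compound 1 in this series. No measurement offered here explains why the number is so sensitive to this small change.

From the compounds shown here alone, whether the number keeps rising along a longer chain, such as propyl, or levels off near that of compound 1 remains open. Compound 1 and compound 3 also differ in both the double bond and the chlorine, so only a compound carrying a plain ethenyl group at this place could show how each of the two contributes.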